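Benzyl to naphthalen-1-yl: solubility expected to fall

This account rests on a few compounds, and the source may have more. Where it says the series, first, only, none or still open, it means among the compounds named here.

Compound 1 `COc1ccc(Oc2ccc3c(NCCCNCc4cc(F)ccc4OC)ccnc3c2)cc1` gives 14500 nM in a physicochemical assay for solubility, with a stated time of 18 h, at pH 7.4; a higher number here means a more soluble compound, a lower number a less soluble compound. Compound 2 `COc1ccc(F)cc1CNCCCNc1ccnc2cc(Cc3ccc(F)cc3)ccc12` gives 4200 nM. Compound 3 `COc1ccc(F)cc1CNCCCNc1ccnc2cc(Cc3ccccc3)ccc12` gives 4200 nM.

Compound 3 sits level with compound 2 and, together with it, at the low end of the three numbers, while a 3.5-fold lower number from compound 1 to compound 3 (0.54 log units; beyond the scatter). Compound 4 `COc1ccc(F)cc1CNCCCNc1ccnc2cc(-c3cccc4ccccc34)ccc12` differs from compound 3 in one place: naphthalen-1-yl in place of benzyl on an aromatic carbon. Among the measured compounds shown here, no measured step matches this change. The nearest guides are a 3.5-fold lower number from compound 1 to compound 2 (0.54 log units; beyond the scatter) and a 3.5-fold lower number from compound 1 to compound 3 (0.54 log units; beyond the scatter), both modest falls when the aryl ether gave way to a benzyl group, and no change at the digits printed from compound 2 to compound 3 (within the scatter). A further modest fall is therefore expected for compound 4, a 3.0-fold lower number from compound 3 to compound 4 (0.48 log units; beyond the scatter). Compound 4 is estimated at 1400 nM, within 500 nM to 4000 nM.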

Compound 4, solubility: 32000 nM
Compound 4: middle estimate off by 23-fold (1.36 log units), on the low side, and the stated range ends below it.
By their numbers in this assay, from the lowest: compounds 2 and 3 (each within the scatter of the next); then compound 1; then compound 4.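

Naphthalen-1-yl on this aromatic carbon raises the number in this assay, with a 7.6-fold higher number from compound 3 to compound 4 (0.88 log units; beyond the scatter) and a 7.6-fold higher number from compound 2 to compound 4 (0.88 log units; beyond the scatter) despite bringing more carbon atoms and a second aromatic ring. It also outdoes 4-methoxyphenoxy, with a 2.2-fold higher number from compound 1 to compound 4 (0.34 log units; beyond the scatter) as the step, giving the highest number of the four. The earlier changes at this carbon had shown only a fall or no change.

Nothing available accounts for this rise. On these data alone, whether naphthalen-2-yl or a directly attached phenyl on this carbon would track compound 4 or compound 3 stays open.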